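The source may hold more compounds than are shown below. What is called first, only, known or untested is meant among the compounds shown, and "the series" means these compounds.

In an ADME assay on HepG2 2.2.15 cells (Homo sapiens) for cytotoxicity (on this read-out higher numbers stand for lower toxicity in this test and lower numbers for higher toxicity in this test), three compounds sharing one core have been measured, differing in the group on a carbonyl carbon. Compound 1 `N#CCC(=O)OCCc1c(-c2ccccc2Cl)c2cc(Cl)ccc2[nH]c1=O`, with cyanomethyl there, gives 100000 nM. Compound 2 `O=C(OCCc1c(-c2ccccc2Cl)c2cc(Cl)ccc2[nH]c1=O)c1ccc([N+](=O)[O-])cc1`, with 4-nitrophenyl, gives 1600000 nM. Compound 3 `COc1ccccc1/C=C/C(=O)OCCc1c(-c2ccccc2Cl)c2cc(Cl)ccc2[nH]c1=O`, with 2-(2-methoxyphenyl)ethenyl, gives 770000 nM, the second highest number of the three and closer to compound 2 than to compound 1.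

Compound 4 `COc1ccc(/C=C/C(=O)OCCc2c(-c3ccccc3Cl)c3cc(Cl)ccc3[nH]c2=O)cc1` has the same atoms as compound 3, joined differently: 4-methoxyphenyl in place of 2-methoxyphenyl on a double-bonded chain carbon bound to a double-bonded chain carbon. Here, 4-methoxyphenyl stands in place of 2-methoxyphenyl on a double-bonded chain carbon bound to a double-bonded chain carbon.

Within the data shown here, no measured step makes this exact change, so the evidence is indirect. Replacing cyanomethyl gave large or modest steps, a 16-fold higher number from compound 1 to compound 2 (1.20 log units; beyond the scatter) and a 7.7-fold higher number from compound 1 to compound 3 (0.89 log units; beyond the scatter), but cyanomethyl holds no aromatic ring. The closer guide is a 2.1-fold lower number from compound 2 to compound 3 (0.32 log units; beyond the scatter), an exchange between two groups that each hold an aromatic ring, and it is the smallest of the three. On that evidence, no step beyond the scatter is expected in this assay, and no direction can be favoured. The expected result is a 1.0-fold higher number from compound 3 to compound 4 (0.02 log units; within the scatter). Compound 4 is estimated at 800000 nM, with an expected range from 300000 nM to 2000000 nM.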

Compound 4, half-maximal cytotoxic concentration: > 1200000 nM
Compound 4 gave a limit, no number; the forecaster's own chance of this, stated with the estimate: 10%; at least 1.5-fold (0.17 log units) between middle value and limit.
By their numbers in this assay, from the lowest: compound 1; then compound 3; then compound 2.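

In this assay compound 4 gives a limit and not a number: the limit of > 1200000 nM in this assay, at which 1 of the 4 values shown sits. From the compounds shown here alone, until now, the data held no change that only moved the methoxy group, and this exchange of 2-methoxyphenyl for 4-methoxyphenyl, on a double-bonded chain carbon bound to a double-bonded chain carbon, gives an at least 1.5-fold higher number from compound 3 to compound 4 (0.19 log units; that floor lies within the scatter), so the floor of this step does not by itself establish a real separation between the two, while its true size remains unknown. Against the cyanomethyl ester, the picture is clearer, with an at least 12-fold higher number from compound 1 to compound 4 (1.07 log units; beyond the scatter), so all three compounds with an aromatic ring in the group on the carbonyl carbon give higher numbers than compound 1, and none of the compounds shown goes against this, although the step between compound 2 and compound 4 cannot be read.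

The compounds shown leave open how far the true value of compound 4 lies past its limit, and so how large the effect of moving the methoxy group really is. They also leave open whether an amine or a carboxylic acid in place of the methoxy group, at either place on the ring, would keep the number as high.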